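Cyano in place of hydrogen on the bromo-bearing ring

The source may hold more compounds than are shown below. What is called first, only, known or untested is meant among the compounds shown, and "the series" means these compounds.

Measured compounds:
compound 1, `FC(F)(F)Oc1ccc(/N=c2\ssnc2Cl)cc1Br`: 73000 nM
compound 2, `Clc1nss/c1=N\c1cccc(Br)c1`: 6700 nM

In a functional assay on MCF7 cells (Homo sapiens) for cytotoxicity, read by resazurin assay, with a stated time of 72 h (on this read-out higher numbers stand for weaker inhibition and lower numbers for stronger inhibition), compound 2 gives 6700 nM, the lowest of the two numbers measured; the nearest is compound 1, which in this assay gives 73000 nM. Among the measured compounds shown here, the one step measured so far, an 11-fold lower number from compound 1 to compound 2 (1.04 log units; beyond the scatter), concerns hydrogen in place of trifluoromethoxy on an aromatic carbon.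

Compound 3, `N#Cc1c(Br)cccc1/N=c1\ssnc1Cl`, is not yet measured. It differs from compound 2 by cyano in place of hydrogen on an aromatic carbon, on a six-membered aromatic ring of carbon only, ortho to a bromo group.

For the measured compounds named here, no measured step involves a cyano group, and the only step in hand, an 11-fold lower number from compound 1 to compound 2 (1.04 log units; beyond the scatter), removes a group rather than adding one, at a different place on the ring. It therefore gives no direct guide to the change from compound 2 to compound 3. With nothing in the measured pair pointing either way, the expected step of a 1.1-fold lower number from compound 2 to compound 3 (0.05 log units; within the scatter) in this assay is none beyond the scatter, with a wide range to allow for the unknown. Compound 3 is estimated at 6000 nM, between 1500 nM and 25000 nM.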

Compound 3, half-maximal inhibitory concentration: 28000 nM
The estimate for compound 3 lay 4.7-fold (0.67 log units) below the measured number; measured number above the stated range.
By their numbers in this assay, from the lowest: compound 2; then compound 3; then compound 1.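

In this assay, cyano at this position, ortho to a bromo group and ortho to a group of 7 heavy atoms, gives a 4.2-fold higher number from compound 2 to compound 3 (0.62 log units; beyond the scatter) and so is not a neutral change. Read with an 11-fold lower number from compound 1 to compound 2 (1.04 log units; beyond the scatter), which concerns trifluoromethoxy at a different place on the ring, this leaves compound 2, the compound without either group, with the lowest number of the three, although two steps are a narrow basis for any wider pattern on this ring. The data shown hold nothing that accounts for the size or direction of this step.

As far as these compounds go, whether the higher number belongs to cyano itself or would follow any group on this carbon remains open, and a methyl group, an amine or a carboxylic acid at the same place would help to separate the two readings. The contribution of the bromo group also remains open, since every compound shown carries it, so its replacement by hydrogen or by chlorine on the same ring would be informative.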